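From a Bromopyrazole to a Methylthiazole

This account rests on a few compounds, and the source may have more. Where it says the series, first, only, none or still open, it means among the compounds named here.

Compound 3 `CN(C)C(=O)C1CCN(c2cnccc2-n2cc(Br)cn2)CC1` stands highest of the three compounds measured in a physicochemical assay for lipophilicity, at pH 7.4; a higher number here means a more lipophilic compound, a lower number a more polar compound: compound 3 gives 2.1. Its nearest neighbour is compound 2 `Cc1cnn(-c2ccncc2N2CCC(C(=O)N(C)C)CC2)c1`, which in this assay gives 1.6, and the furthest is compound 1 `CN(C)C(=O)C1CCN(c2cnccc2-n2cccn2)CC1`, for which compound 1 gives 1.1 in this assay. All three steps between them lie beyond the scatter: a number 0.50 log units higher from compound 1 to compound 2 (beyond the scatter), a number 1.00 log units higher from compound 1 to compound 3 (beyond the scatter) and a number 0.50 log units higher from compound 2 to compound 3 (beyond the scatter).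

Compound 4 `Cc1cnc(-c2ccncc2N2CCC(C(=O)N(C)C)CC2)s1` differs from compound 3 in one place: 5-methyl-1,3-thiazol-2-yl in place of 4-bromo-1H-pyrazol-1-yl on an aromatic carbon. Among the measured compounds shown here, none of the measured steps bears directly on this exchange. Each of them swapped a single substituent on the same five-membered ring, whereas here the whole ring leaves and a different one enters. What the measured steps do show is that changes on this part of the molecule have moved the number in this assay only modestly, and that both a methyl and a bromo on that ring raised it. Since compound 4 keeps a methyl on its new ring while the bromo is lost, compound 4 is expected to stay near the top of the series, with an estimated step of a number 0.10 log units higher from compound 3 to compound 4 (within the scatter) that is within the scatter. The estimate for compound 4 in this assay is 2.2, with a range from 1.6 to 2.8.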

Compound 4, distribution coefficient: 2
Compound 4: middle estimate off by 0.20 log units, on the high side; the range from low to high includes it.
By their numbers in this assay, from the lowest: compound 1; then compound 2; then compounds 4 and 3 (each within the scatter of the next).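

In this assay, this position tolerated the exchange of the whole five-membered ring, not only of a substituent on it, and the step that resulted cannot be told from the scatter: a number 0.10 log units lower from compound 3 to compound 4 (within the scatter). The 5-methyl-1,3-thiazol-2-yl and 4-bromo-1H-pyrazol-1-yl groups, which differ in their atoms and in their substituent, therefore cannot be separated by this read-out. Yet the change of ring is not silent in every pair, for the new group stands clear of both simpler pyrazoles, with a number 0.40 log units higher from compound 2 to compound 4 (beyond the scatter) and a number 0.90 log units higher from compound 1 to compound 4 (beyond the scatter); since a methyl is present on the ring on both sides of the first of these steps, the number at this position depends on more than the substituent alone.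

Nothing available explains why these rings give the numbers they do. On these data alone, it remains open how far the methyl contributes on the thiazole ring, which would take the 1,3-thiazol-2-yl group without it, and whether an amine or a carboxylic acid on the five-membered ring would carry the number in this assay outside the narrow span seen so far.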